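Acetamido for bromo in a series without readable values

The source may hold more compounds than are shown below. What is called first, only, known or untested is meant among the compounds shown, and "the series" means these compounds.

Of the compounds shown here, three with a shared core have been tested, differing in one group on an aromatic ring: compound 1 `CCCCOc1cccc(-c2[nH]c3cc(OC)ccc3c(=O)c2C(=O)OCC)c1` and compound 2 `CCOC(=O)c1c(-c2cccc(Oc3ccccc3)c2)[nH]c2cc(OC)ccc2c1=O` and compound 3 `CCOC(=O)c1c(-c2cccc(Br)c2)[nH]c2cc(OC)ccc2c1=O` in turn. In an ADME assay on Raji cells (Homo sapiens) for cytotoxicity, read by luminescence, with a stated time of 72 h (on this read-out lower numbers stand for an effect already at smaller amounts and higher numbers for an effect only at larger amounts of compound), compound 1 gives > 21500 nM as a limit and not a number. In this assay compound 2 gives > 21500 nM as a limit too. In this assay compound 3 gives > 21500 nM as a limit as well. Compound 3 thus stands with the others at the limit of > 21500 nM in this assay, at which 3 of the 3 values shown sit, and no order among them can be read.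

Compound 4 `CCOC(=O)c1c(-c2cccc(NC(C)=O)c2)[nH]c2cc(OC)ccc2c1=O` carries acetamido in place of bromo on an aromatic carbon, meta to a large group (acetamido in place of bromo on an aromatic carbon). Changes at this same place give a step that the two limits leave unreadable from compound 1 to compound 3 and a step that the two limits leave unreadable from compound 2 to compound 3 and also a step that the two limits leave unreadable from compound 1 to compound 2 with no size to carry over. No step beyond the scatter is therefore expected in this assay and no direction either. The expected change is a step that the limit leaves unreadable from compound 3 to compound 4 by this estimate. Compound 4 is estimated at 25000 nM with an expected range from 10000 nM to 60000 nM and will probably report a limit again.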

Compound 4, half-maximal effective concentration: > 21500 nM
Compound 4 gave a limit, no number; the forecaster's own chance of this, stated with the estimate: 85%; the middle value is on the limit's open side.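

In this assay compound 4 gives > 21500 nM, a limit and not a number. Among these compounds, no step between compound 4 and compound 1, compound 2 or compound 3 can therefore be read: the limit of > 21500 nM in this assay, at which 4 of the 4 values shown sit.

The compounds shown leave open whether butoxy, phenoxy, bromo and acetamido differ at all in their effect on these cells.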